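The source may hold more compounds than are shown below. What is called first, only, known or untested is meant among the compounds shown, and "the series" means these compounds.

The measured compounds:
Compound 1 `Cn1c(=O)c(=O)n(C2CCCC2)c2nc(N/N=C/c3ccccc3)ncc21`; in a functional assay on A549 cells (Homo sapiens) for antiproliferative activity, read by MTT assay (a higher number here means a weaker inhibitor, a lower number a stronger inhibitor), compound 1 gives > 100000 nM, which is a limit of the assay rather than a number.
Compound 2 `Cc1cccc(/C=N/Nc2ncc3c(n2)n(C2CCCC2)c(=O)c(=O)n3C)c1`; compound 2 gives 34500 nM.
Compound 3 `Cn1c(=O)c(=O)n(C2CCCC2)c2nc(N/N=C/c3ccco3)ncc21`; compound 3 gives > 100000 nM, again a limit.

Compound 1 thus stands at the limit (the limit of > 100000 nM in this assay, at which 2 of the 3 values shown sit). Compound 4 `Cc1ccc(/C=N/Nc2ncc3c(n2)n(C2CCCC2)c(=O)c(=O)n3C)cc1C` differs from compound 1 by 3,4-dimethylphenyl in place of phenyl on a carbon with a double bond to nitrogen. Among the compounds with values here, the one measured step that bears on this change is an at least 2.8-fold lower number from compound 1 to compound 2 (0.46 log units; beyond the scatter), where a methyl in place of hydrogen on an aromatic carbon was enough to bring the value down from the limit. A second methyl has no measured counterpart among these compounds, so its own contribution is open. Compound 4 is therefore expected to show an at least 4.0-fold lower number from compound 1 to compound 4 (0.60 log units; beyond the scatter), toward a stronger inhibitor. Compound 4 is estimated at 25000 nM, with a range from 8000 nM to 100000 nM.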

Compound 4, half-maximal inhibitory concentration: 30200 nM
Beside the measured number, compound 4's estimate is 1.2-fold (0.08 log units) below it, within the range that was stated.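

In this assay, a second methyl gives a 1.1-fold lower number from compound 2 to compound 4 (0.06 log units; within the scatter), so compound 4 and compound 2 cannot be told apart and the added methyl shows no readable gain. Against the unmethylated phenyl and the furan-2-yl there is an at least 3.3-fold lower number from compound 1 to compound 4 (0.51 log units; beyond the scatter) and an at least 3.3-fold lower number from compound 3 to compound 4 (0.51 log units; beyond the scatter). Both steps start from a limit of the assay, so only their minimum size is known: the limit of > 100000 nM in this assay, at which 2 of the 4 values shown sit.

The compounds shown leave open whether a different group on this ring, such as a methoxy, an amine or a carboxylic acid, would move the value further.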